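A few compounds are considered here, and "the series" means these few. Any claim that something is new, unique, unknown or untested is made for them only; others in the source may bear on it.

In a physicochemical assay for solubility, read by turbidimetry, measured as kinetic solubility, at pH 6.8 (on this read-out lower numbers stand for lower solubility and higher numbers for higher solubility), the measured compounds stand as follows
Compound 1 `COc1ccc(F)cc1N1C(=O)CSC1c1cccc(C(=O)NCCCCc2ccccc2)c1` gives 10000 nM
Compound 2 `C#Cc1cccc(N2C(=O)CSC2c2cccc(C(=O)NCCCCc3ccccc3)c2)c1` gives 10000 nM

Compound 2 stands level with compound 1 at the digits reported, and compound 1 is its nearest neighbour. Compound 3 `O=C(NCCCCc1ccccc1)c1cccc(C2SCC(=O)N2c2ccc(C3CC3)cc2)c1` has not yet been measured. It keeps the shared core and carries 4-cyclopropylphenyl in place of 3-ethynylphenyl on an amide-type nitrogen in a ring. Among the measured compounds shown here, one measured step bears on this change, made on that same nitrogen (no change at the digits printed from compound 1 to compound 2 (within the scatter)), and it lies within the scatter. For the measured compounds named here, that is a single step, and the data hold no compound with a cyclopropyl group. No step beyond the scatter is therefore expected in this assay, and no direction can be given. The expected step runs (no change at the digits printed from compound 2 to compound 3 (within the scatter)). For compound 3 the estimated value is 10000 nM in an expected range from 4000 nM to 20000 nM.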

Compound 3, solubility: 2000 nM
Compound 3: the middle estimate sits 5.0-fold (0.70 log units) above what was measured, and the stated range ends above it.
By their numbers in this assay, from the lowest: compound 3; then compounds 1 and 2 (each within the scatter of the next).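

In this assay, the group on the amide-type nitrogen proves able to move the read-out: 4-cyclopropylphenyl in place of 3-ethynylphenyl gives a 5.0-fold lower number from compound 2 to compound 3 (0.70 log units; beyond the scatter), and in place of 5-fluoro-2-methoxyphenyl it gives a 5.0-fold lower number from compound 1 to compound 3 (0.70 log units; beyond the scatter). The only earlier change at this nitrogen had shown no change at the digits printed from compound 1 to compound 2 (within the scatter), so compound 3, the one compound here with a three-membered ring, is the first to separate from the others. No supporting measurement accounts for this step.

The compounds shown do not separate the cyclopropyl group from its placement on the phenyl ring, as compound 3 differs from compound 2 in both. Also open, on these data alone, is how this assay would read with an amine or a carboxylic acid on that phenyl ring.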